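Two Flat Amines and a Piperazine Amide Follow-up

The source may hold more compounds than are shown below. What is called first, only, known or untested is meant among the compounds shown, and "the series" means these compounds.

Measured so far:
compound 1 `N#CCN(Cc1ccc2ccccc2c1)Cc1ccccc1Br`: 0%
compound 2 `N#CCCCN(Cc1ccccc1)Cc1ccc2ccccc2c1`: 0%

In an assay on HEK293 cells for binding affinity to Substance-K receptor (Rattus norvegicus), read by FRET, tested at 10 uM (on this read-out higher numbers stand for more inhibition at the one concentration tested (going by the name of the read-out) and lower numbers for less inhibition), compound 1 gives 0%. In this assay compound 2 gives 0%, level with compound 1 within the scatter. Compound 3 `CN1CCN(C(=O)CN(Cc2ccccc2)Cc2ccc3ccccc3c2)CC1` carries one change from compound 2: (4-methylpiperazin-1-yl)carbonyl in place of 2-cyanoethyl on a saturated chain carbon bound to an amine nitrogen. Within the data shown here, no step between measured compounds is known, so nothing shows how this change acts. Because compound 2 sits at 0%, the expected step of a number 5 percentage points higher from compound 2 to compound 3 (within the scatter) is none beyond the scatter. Compound 3 is estimated at 5%, with a range from -10% to 25%.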

Compound 3, a percentage reported as inhibition, at one concentration (the size of the read-out at that concentration, not a potency): 0%
Compound 3: middle estimate off by 5 percentage points, on the high side; the range from low to high includes it.
By their numbers in this assay, from the lowest: compounds 1, 2 and 3 (each within the scatter of the next).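

In this assay the replacement of 2-cyanoethyl by (4-methylpiperazin-1-yl)carbonyl on a saturated chain carbon bound to an amine nitrogen gives no change at the digits printed from compound 2 to compound 3 (within the scatter) at this position. So a much larger group carrying a six-membered non-aromatic ring and a carbonyl still produces no measurable inhibition here, though with both compounds at the same reading the step cannot separate the two groups. No supporting evidence bears on this result. Still open, going by these compounds, is whether a carboxylic acid or a primary amine on a longer chain at this position would give a reading beyond the scatter.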